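Methyl in place of nitro: a cytotoxicity estimate

The compounds below may be only part of what the source reports. "The series", "measured", "known", "first", "only" and "open" are said of these compounds alone.

Compound 1 `CN(C)CCCN(/N=N/c1ccc([N+](=O)[O-])cc1)c1ccccc1`: 39000 nM
Compound 2 `CN(C)CCCNc1ccc(/N=N/c2c(F)cccc2F)cc1`: 20000 nM

In an ADME assay on MDBK cells (Bos taurus) for cytotoxicity, read by MTT assay, with a stated time of 96 h (on this read-out lower numbers stand for higher toxicity in this test and higher numbers for lower toxicity in this test), compound 1 gives 39000 nM, which lies within the usual scatter of compound 2 at 20000 nM, so these two numbers show no real order. Compound 3 `Cc1ccc(/N=N/N(CCCN(C)C)c2ccccc2)cc1` keeps the core of compound 1 and changes one group: methyl in place of nitro on an aromatic carbon. Among the compounds with values here, no measured pair shows what this swap does, so no change beyond the scatter is expected in this assay. The expected step is a 1.3-fold lower number from compound 1 to compound 3 (0.11 log units; within the scatter). For compound 3 the estimate is 30000 nM, with a range of 10000 nM to 90000 nM.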

Compound 3, half-maximal cytotoxic concentration: > 100000 nM
Compound 3: no number, only a limit; the forecaster's own chance of this, stated with the estimate: 15%; at least 3.3-fold (0.52 log units) between middle value and limit.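

In this assay, methyl in place of nitro on an aromatic carbon, para to a large group, gives an at least 2.5-fold higher number from compound 1 to compound 3 (0.40 log units; beyond the scatter), so this single change moves the read-out towards lower toxicity in this test. Compound 3 gives > 100000 nM, which is a limit and not a number. The full size of the step therefore stays unknown, because the reading stops at that limit: the limit of > 100000 nM in this assay, at which 1 of the 3 values shown sits.

Going by these compounds, it remains open whether losing nitro or gaining methyl matters more. An amine or a chlorine atom at this position could help separate the two.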